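The source may hold more compounds than are shown below. What is called first, only, known or untested is meant among the compounds shown, and "the series" means these compounds.

Measured so far in a functional assay on MCF7 cells (Homo sapiens) for cytotoxicity, read by MTT assay, with a stated time of 72 h; on this read-out higher numbers stand for weaker inhibition and lower numbers for stronger inhibition:
Compound 1, `O=C(Nc1ccc(Oc2ccnc3[nH]ccc23)cc1)c1cc(-c2ccc(C(F)(F)F)cc2)ccn1`, gives > 10000 nM, which is a limit of the assay.
Compound 2, `Cc1ccc(-c2ccnc(C(=O)Nc3ccc(Oc4ccnc5[nH]ccc45)c(F)c3)c2)cc1`, gives 8430 nM.
Compound 3, `Cc1ccc(-c2ccnc(C(=O)Nc3ccc(Oc4ccnc5[nH]ccc45)c(F)c3)c2)c(C)c1`, gives 6220 nM.

Compound 3 holds the lowest of the two numbers, compound 2 being nearest; the step of a 1.4-fold lower number from compound 2 to compound 3 (0.13 log units; within the scatter) stays within the scatter. Compound 4, `O=C(Nc1ccc(Oc2ccnc3[nH]ccc23)c(F)c1)c1cc(-c2ccc(C(F)(F)F)cc2)ccn1`, differs from compound 3 by 4-(trifluoromethyl)phenyl in place of 2,4-dimethylphenyl on an aromatic carbon. Among the measured compounds shown here, no measured step covers this exchange of aryl groups; the one recorded step, a 1.4-fold lower number from compound 2 to compound 3 (0.13 log units; within the scatter), concerns methyl groups and lies within the scatter. For the measured compounds named here, compound 1 carries the same 4-(trifluoromethyl)phenyl and sits at the limit (the limit of > 10000 nM in this assay, at which 1 of the 3 values shown sits); it lacks the fluorine of compound 4, and its value shows only that no number below the limit was reached. Compound 4 is therefore expected at 9500 nM, between 4000 nM and 22000 nM, a step of a 1.5-fold higher number from compound 3 to compound 4 (0.18 log units; within the scatter) that may not exceed the scatter, with a fair chance of a limit only.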

Compound 4, half-maximal inhibitory concentration: 8550 nM
The estimate for compound 4 lay 1.1-fold (0.05 log units) above the measured number, and the stated range covers the measured number.
By their numbers in this assay, from the lowest: compounds 3, 2 and 4 (each within the scatter of the next). At a limit, above all of these: compound 1.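

In this assay the exchange of aryl groups on this aromatic carbon, opposite the ring nitrogen, stays within the scatter (a 1.4-fold higher number from compound 3 to compound 4 (0.14 log units; within the scatter)). Trifluoromethyl in place of methyl likewise shows no change beyond the scatter (a 1.0-fold higher number from compound 2 to compound 4 (0.01 log units; within the scatter)). Fluoro in place of hydrogen can be read only as a floor (an at least 1.1-fold lower number from compound 1 to compound 4 (0.06 log units; that floor lies within the scatter)) because compound 1 stands at a limit: the limit of > 10000 nM in this assay, at which 1 of the 4 values shown sits.

From the compounds shown here alone, the size of the fluoro step remains open. So does whether an amine or a carboxylic acid on this aryl ring would move the number beyond the scatter.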